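A few compounds are considered here, and "the series" means these few. Any claim that something is new, unique, unknown or untested is made for them only; others in the source may bear on it.

In a functional assay on KB cells (Homo sapiens) for antiproliferative activity, read by MTT assay, with a stated time of 72 h (on this read-out lower numbers stand for stronger inhibition and higher numbers for weaker inhibition), compound 1 `CCOC(=O)c1cc(-c2ccc(OC)cc2)c(-c2cc(OC)c(OC)c(OC)c2)s1` gives 10200 nM and compound 2 `CCOC(=O)c1cc(-c2ccc(OC)c([N+](=O)[O-])c2)c(-c2cc(OC)c(OC)c(OC)c2)s1` gives 24000 nM. Compound 3 `CCOC(=O)c1cc(-c2ccc(OC)c(OCc3ccccc3)c2)c(-c2cc(OC)c(OC)c(OC)c2)s1` gives > 100000 nM, which is a limit of the assay and not a number. Within the data shown here, compound 3 therefore has no exact position on the scale, and only the steps towards it can be sized.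

Compound 4 `CCOC(=O)c1cc(-c2ccc(OC)c(O)c2)c(-c2cc(OC)c(OC)c(OC)c2)s1` is derived from compound 3 by one change, benzyloxy to hydroxy, with hydrogen in place of benzyl on an oxygen on an aromatic ring. Among the measured compounds shown here, no measured step involves hydroxy itself, so the evidence is indirect. Two steps lead to the benzyloxy group: an at least 9.8-fold higher number from compound 1 to compound 3 (0.99 log units; beyond the scatter) and an at least 4.1-fold higher number from compound 2 to compound 3 (0.61 log units; beyond the scatter). A third step shows a smaller effect on adding a group at that place: a 2.4-fold higher number from compound 1 to compound 2 (0.37 log units; beyond the scatter).

Removing the benzyl group is thus expected to reverse much of the loss seen on reaching compound 3 and to bring the number back towards the region of compound 1 and compound 2. In this assay, the expected step is an at least 11-fold lower number from compound 3 to compound 4 (1.04 log units; beyond the scatter), towards a lower number and beyond the scatter. For compound 4 the estimated value is 9000 nM, with an expected range from 2000 nM to 35000 nM.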

Compound 4, half-maximal inhibitory concentration: > 100000 nM
Compound 4: no number, only a limit; the forecaster's own chance of this, stated with the estimate: 8%; middle value at least 11-fold (1.04 log units) away from the limit.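

Compound 4 gives > 100000 nM in this assay, which is a limit of the assay and not a number, and the step to it from compound 3 cannot be read: the limit of > 100000 nM in this assay, at which 2 of the 4 values shown sit. The steps from the two compounds with a measured number can be read, and hydroxy at this place stands with an at least 9.8-fold higher number from compound 1 to compound 4 (0.99 log units; beyond the scatter) and with an at least 4.1-fold higher number from compound 2 to compound 4 (0.61 log units; beyond the scatter). The earlier compounds tied the loss at this place to benzyloxy alone, whereas this result shows that taking off the benzyl group, with its seven carbon atoms and aromatic ring, does not bring the number back to the region of compound 1 and compound 2, so among the four compounds shown only hydrogen and nitro at this place give a measured number.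

Going by these compounds, how far compound 3 and compound 4 lie beyond the limit stays open, and with it whether the two differ at all in this assay. The compounds shown also leave open how other groups at this place would read, such as an amine, a fluorine atom or a methoxy group, and whether any of them would stay near compound 1.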